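Trimming propoxy to ethoxy on a shared core

The compounds below may be only part of what the source reports. "The series", "measured", "known", "first", "only" and "open" are said of these compounds alone.

Of the compounds shown here, three built on one shared core have been measured in an ADME assay on Akata cells (Homo sapiens) for cytotoxicity, with a stated time of 7 days; a lower number here means that less compound is tolerated, a higher number that more compound is tolerated. Compound 1 `Nc1nc(NC2CCCCC2)c2ncn(/C=C3/CC3(CO)CO)c2n1` reaches only a limit there, giving > 24000 nM. Compound 2 `CCCOc1nc(N)nc2c1ncn2/C=C1/CC1(CO)CO` also gives only a limit, > 20000 nM. Compound 3 `CSc1nc(N)nc2c1ncn2/C=C1/CC1(CO)CO` gives > 20000 nM, again a limit. Compound 2 thus stands at the limit of > 20000 nM in this assay, at which 2 of the 3 values shown sit, a place it shares with compound 3, while compound 1 sits at the limit of > 24000 nM in this assay, at which 1 of the 3 values shown sits. The steps a step that the two limits leave unreadable from compound 1 to compound 2, a step that the two limits leave unreadable from compound 1 to compound 3 and a step that the two limits leave unreadable from compound 2 to compound 3 have limits at both ends, so no size can be read from any of them.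

Compound 4 `CCOc1nc(N)nc2c1ncn2/C=C1/CC1(CO)CO` differs from compound 2 by hydrogen in place of methyl on a saturated chain carbon, two bonds along the chain from an oxygen on an aromatic ring. Within the data shown here, none of the measured steps concerns this kind of change; all three exchange a group on an aromatic carbon, and all three are unreadable. Every value shown is a limit, and nothing among them points to a change in tolerance. Compound 4 is therefore expected to give 25000 nM, with a range from 12000 nM to 60000 nM. The step that the limit leaves unreadable from compound 2 to compound 4 is expected to be none beyond the scatter, with the assay most likely reporting only a limit again.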

Compound 4, half-maximal cytotoxic concentration: > 20000 nM
Compound 4 gave a limit, no number (the forecaster's own chance of this, stated with the estimate: 85%); the middle value is on the limit's open side.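

Compound 4 gives only a limit, so its steps from compound 1, compound 2 and compound 3 have limits at both ends and none can be read. The compounds shown leave open where the tolerance of any of the four actually lies, and whether propoxy to ethoxy changes it.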